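The source may report more compounds than this note shows. Statements on the series, on what has been measured and on what is new or still open speak of the compounds shown alone.

Compounds measured in an assay on HeLa cells for displacement of a labelled ligand from 5-hydroxytryptamine receptor 6 (Homo sapiens), with a stated time of 2 h; a higher number here means a weaker inhibitor, a lower number a stronger inhibitor:
- Compound 1, `COc1ccc2c(c1)c(S(=O)(=O)c1cccc(F)c1)cn2C1CCCNC1`: 10.7 nM
- Compound 2, `COc1ccc2c(c1)c(S(=O)(=O)c1cccc(F)c1)cn2C1CCCN(C)C1`: 68 nM
- Compound 3, `O=S(=O)(c1cccc(F)c1)c1cn(C2CCNC2)c2ccc(F)cc12`: 9.6 nM

Compound 1 and compound 2 share a core and differ in one place, (methyl in place of hydrogen on an amine nitrogen in a ring). That change made a 6.4-fold higher number from compound 1 to compound 2 (0.80 log units; beyond the scatter). Compound 3 carries a different core; the difference between the two cores is not broken down here. In this assay compound 3 and compound 1 sit within the scatter of each other, so nothing can be said about which is the stronger inhibitor.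

Compound 4, `CN1CCC(n2cc(S(=O)(=O)c3cccc(F)c3)c3cc(F)ccc32)C1`, has not yet been measured in this assay. It differs from compound 3 by methyl in place of hydrogen on an amine nitrogen in a ring. For the measured compounds named here, this is the same kind of change as the one from compound 1 to compound 2, not the same change: in compound 1 the amine nitrogen sits in a six-membered non-aromatic ring with 1 nitrogen, while in compound 3 it sits in a five-membered non-aromatic ring with 1 nitrogen, in both cases two ring bonds from the ring atom that bears a large group.

Going by the values given here, the expectation for compound 4 rests on the one measured step of this kind, a 6.4-fold higher number from compound 1 to compound 2 (0.80 log units; beyond the scatter), and is a step of about a 5.2-fold higher number from compound 3 to compound 4 (0.72 log units; beyond the scatter), with some room for the smaller ring to behave differently. Compound 4 is therefore estimated at 50 nM in this assay, likely between 18 nM and 140 nM.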

Compound 4, inhibition constant: 5 nM
For compound 4 the middle estimate is 10-fold (1.00 log units) above the measured one, and the stated range ends above it.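

In this assay, methyl in place of hydrogen on the amine nitrogen of the five-membered ring gives a 1.9-fold lower number from compound 3 to compound 4 (0.28 log units; within the scatter), so this pair cannot be ranked and the methyl leaves no readable mark on this core. The loss seen on the other core, a 6.4-fold higher number from compound 1 to compound 2 (0.80 log units; beyond the scatter), therefore does not carry over as a fixed penalty, and the two steps really do differ in size: the same change on two cores in this assay, a 6.4-fold higher number (0.80 log units; beyond the scatter) from compound 1 to compound 2 and a 1.9-fold lower number (0.28 log units; within the scatter) from compound 3 to compound 4, 12-fold (1.09 log units) apart, beyond the scatter of two such steps. For the compounds shown here, this shows that the effect of this methyl depends on the core that carries it, but it does not show which part of the core matters, since the two cores differ both in the amine ring, six-membered in one and five-membered in the other, and in having a methoxy group or a fluorine, and each core offers only one pair.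

A pair with the five-membered amine ring and the methoxy group, or the six-membered ring and the fluorine, would be needed to separate these two differences. The compounds shown also leave open how a longer chain such as ethyl, or an acetyl group, on that same nitrogen would read on either core.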